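Amide to trifluoromethyl ketone swap on two aryl cores

A few compounds are considered here, and "the series" means these few. Any claim that something is new, unique, unknown or untested is made for them only; others in the source may bear on it.

Measured so far in an assay (Rattus norvegicus) for inhibition of Fatty-acid amide hydrolase 1 (Homo sapiens); a lower number here means a stronger inhibitor, a higher number a weaker inhibitor:
compound 1 `NC(=O)c1cccc(-c2cnc(C(=O)CCCCCCc3ccccc3)o2)c1` gives 6 nM
compound 2 `O=C(CCCCCCc1ccccc1)c1ncc(-c2cccc(C(=O)C(F)(F)F)c2)o1` gives 16 nM
compound 3 `NC(=O)c1ccc(-c2cnc(C(=O)CCCCCCc3ccccc3)o2)cc1` gives 10 nM

Compound 1 and compound 2 differ by one change: trifluoromethyl in place of amino on a carbonyl carbon. That change made a 2.7-fold higher number from compound 1 to compound 2 (0.43 log units; beyond the scatter), so the trifluoromethyl ketone ends with a higher number than the carbamoyl on this core. Compound 3 carries the other core; the difference is 4-carbamoylphenyl in place of 3-carbamoylphenyl on an aromatic carbon, and it gave a 1.7-fold higher number from compound 1 to compound 3 (0.22 log units; within the scatter), so the two cores sit close to each other in this assay.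

Compound 4 `O=C(CCCCCCc1ccccc1)c1ncc(-c2ccc(C(=O)C(F)(F)F)cc2)o1` has not yet been measured in this assay. It differs from compound 3 by trifluoromethyl in place of amino on a carbonyl carbon. For the measured compounds named here, the place of this change is the same, word for word, as in the step from compound 1 to compound 2, so it is the same change on the other core, and the only instance measured so far is that single earlier step.

Going by the values given here, for compound 4 the expected step is a 2.7-fold higher number from compound 3 to compound 4 (0.43 log units; beyond the scatter), set beside a 2.7-fold higher number from compound 1 to compound 2 (0.43 log units; beyond the scatter) as the one precedent, with the cores themselves close in this assay. Compound 4 is thus estimated at 27 nM, expected to fall between 12 nM and 60 nM.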

Compound 4, inhibition constant: 65 nM
Compound 4: middle estimate off by 2.4-fold (0.38 log units), on the low side, outside the stated range (above it).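

In this assay the swap from carbamoyl to (trifluoromethyl)carbonyl goes the same way on the second core, with a 6.5-fold higher number from compound 3 to compound 4 (0.81 log units; beyond the scatter), so the direction of the change carries from the core of compound 1 to the core of compound 3. The two step sizes cannot be told apart, and the larger number on the second core is no sign of a core dependence: the same change on two cores in this assay, a 2.7-fold higher number (0.43 log units; beyond the scatter) from compound 1 to compound 2 and a 6.5-fold higher number (0.81 log units; beyond the scatter) from compound 3 to compound 4, 2.4-fold (0.39 log units) apart, within the scatter of two such steps. This is one pair of steps on two closely related cores, so it does not show that the change would behave alike on any further core, and it does not say what lies behind the higher numbers.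

Left open is whether a carboxylic acid or a nitrile in place of the carbamoyl would keep the same order on both cores. Also open, from the compounds shown here alone, is whether the step holds with a longer chain in place of the one shared by all four compounds.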